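This account rests on a few compounds, and the source may have more. Where it says the series, first, only, none or still open, it means among the compounds named here.

Among the measured compounds shown here, compound 2 `COc1ccc(Cl)cc1NS(=O)(=O)c1ccc(OC)c(N2CCNCC2)c1` stands highest of the two numbers so far in an assay on isolated protein for binding affinity to 5-hydroxytryptamine receptor 6 (Homo sapiens) (a lower number here means a stronger inhibitor, a higher number a weaker inhibitor), giving 1.26 nM. Its nearest neighbour is compound 1 `COc1ccc(S(=O)(=O)Nc2cccc(I)c2)cc1N1CCNCC1`, which in this assay gives 0.501 nM. For the measured compounds named here, the single step joining them, a 2.5-fold higher number from compound 1 to compound 2 (0.40 log units; beyond the scatter), came with 5-chloro-2-methoxyphenyl in place of 3-iodophenyl on a sulfonamide nitrogen, a modest move beyond the scatter.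

Compound 3 `COc1ccc(S(=O)(=O)Nc2cc(Br)cc(F)c2Cl)cc1N1CCNCC1` is the next member. How it differs from compound 2: 5-bromo-2-chloro-3-fluorophenyl in place of 5-chloro-2-methoxyphenyl on a sulfonamide nitrogen.

Going by the values given here, only one measured step bears on this change, a 2.5-fold higher number from compound 1 to compound 2 (0.40 log units; beyond the scatter), since it too exchanged the aryl on the sulfonamide nitrogen for another of similar size and shifted the number by a modest amount. The step to compound 3 is of the same kind: one six-membered carbon aromatic ring leaves and another enters at the sulfonamide nitrogen, with a halogen pattern not yet seen in the series and no hydrogen-bond acceptor on the entering ring. Nothing measured here separates the effect of that pattern from ordinary scatter, so a small step in either direction, a 1.3-fold lower number from compound 2 to compound 3 (0.10 log units; within the scatter), is expected. Compound 3 is estimated at 1 nM, with a range from 0.3 nM to 3.5 nM.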

Compound 3, inhibition constant: 3.16 nM
Estimate against measurement, compound 3: 3.2-fold (0.50 log units) below; measured number inside the range.
By their numbers in this assay, from the lowest: compound 1; then compound 2; then compound 3.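

The aryl group on the sulfonamide nitrogen in this assay remains sensitive to its substitution pattern even when the heavy-atom count stays the same: a 2.5-fold higher number from compound 2 to compound 3 (0.40 log units; beyond the scatter) goes with the swap of 5-chloro-2-methoxyphenyl for 5-bromo-2-chloro-3-fluorophenyl. The wider span, a 6.3-fold higher number from compound 1 to compound 3 (0.80 log units; beyond the scatter), is the largest step in the series so far and puts 3-iodophenyl and 5-bromo-2-chloro-3-fluorophenyl at the two ends of the three aryl groups shown. No supporting measurement explains either shift.

Since the entering ring differs from both earlier rings in several substituents at once, the bromine, chlorine and fluorine cannot be assessed separately, and the loss of the methoxy group in the step from 5-chloro-2-methoxyphenyl cannot be separated from the halogen changes. Going by these compounds, it also remains open whether a plain phenyl, a cyclohexyl or a phenyl carrying a carboxylic acid on the sulfonamide nitrogen would stay in this range of numbers.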